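Removing one decenyl chain from compound 3

This account rests on a few compounds, and the source may have more. Where it says the series, first, only, none or still open, it means among the compounds named here.

Compound 1 `CCCCCCCC/C=C\c1c(C)nc(C)c(/C=C\CCCCCCCC)c1C`: > 30 uM (a limit)
Compound 2 `CCCCCCCC/C=C\c1c(C)cc(C)nc1CCCOC`: > 30 uM (a limit)
Compound 3 `CCCCCCCC/C=C\c1c(C)c(/C=C\CCCCCCCC)c2[n+](c1C)CCC2`: 1.1 uM

Among the compounds with values here, in a functional assay on PC-3 cells (Homo sapiens) for antiproliferative activity, read by WST assay, with a stated time of 72 h (a lower number here means that less compound is needed, a higher number that more compound is needed for the effect), compound 3 gives 1.1 uM, the only true number in this small set. Compound 1 and compound 2 each reach only a limit of the assay, and the evidence here is the limit of > 30 uM in this assay, at which 2 of the 3 values shown sit.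

The next compound to be tested is compound 4 `CCCCCCCC/C=C\c1c(C)cc(C)[n+]2c1CCC2`. It carries hydrogen in place of dec-1-en-1-yl on an aromatic carbon, two atoms from the ring nitrogen: hydrogen in place of dec-1-en-1-yl on an aromatic carbon. Within the data shown here, no measured pair in the set shows this change alone, so any expectation is uncertain.

Starting from compound 3 at 1.1 uM, a moderate loss of activity is expected in this assay, with more compound needed and a step beyond the usual scatter. The expected shift is a 5.5-fold higher number from compound 3 to compound 4 (0.74 log units; beyond the scatter). For compound 4 the estimated value is 6 uM, with an expected range from 1.5 uM to 25 uM.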

Compound 4, concentration for half-maximal effect: 0.2 uM
Beside the measured number, compound 4's estimate is 30-fold (1.48 log units) above it; measured number outside the range, below it.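

Within the data shown here, compound 3 and compound 4 form the first pair in the set that differs in one place, and in this assay the change gives a 5.5-fold lower number from compound 3 to compound 4 (0.74 log units; beyond the scatter). The dec-1-en-1-yl group on the aromatic carbon two atoms from the ring nitrogen is therefore not needed for activity, since hydrogen there gives a lower number, a modest gain that lies beyond the scatter. Nothing measured in this set gives a reason for that gain.

A single pair cannot tell whether a shorter chain such as butyl, or an amine, on this same carbon would keep or extend the gain. It also leaves open whether the remaining dec-1-en-1-yl group of compound 4 is itself needed, or whether a shorter chain could stand in its place.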